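The compounds below may be only part of what the source reports. "The series", "measured", "known", "first", "only" and "open" are said of these compounds alone.

Going by the values given here, compound 2 `CCN(CC)C/C=C/C(=O)Nc1cc2c(N3CCCc4ccccc43)ncnc2cc1O[C@@H]1CCOC1` is the lowest of the two numbers so far in a functional assay on PC-3 cells (Homo sapiens) for antiproliferative activity, read by MTT assay, with a stated time of 72 h; a lower number here means a stronger inhibitor, a higher number a weaker inhibitor; compound 2 gives 4270 nM, while compound 1 `CC(C)/C=C/C(=O)Nc1cc2c(N3CCCc4ccccc43)ncnc2cc1O[C@@H]1CCOC1` gives 8510 nM, a gap reported as a 2.0-fold lower number from compound 1 to compound 2 (0.30 log units; within the scatter). Compound 3 `O=C(/C=C/CN1CCC(CO)CC1)Nc1cc2c(N3CCCc4ccccc43)ncnc2cc1O[C@@H]1CCOC1` differs from compound 2 by 4-(hydroxymethyl)piperidin-1-yl in place of diethylamino on a saturated chain carbon bound to a double-bonded chain carbon. Among the compounds with values here, only that single step bears on this change, and it stayed within the scatter, so no step beyond the scatter is expected in this assay. Compound 3 is therefore estimated at 3500 nM, with a range of 1200 nM to 10000 nM, which would mean a 1.2-fold lower number from compound 2 to compound 3 (0.09 log units; within the scatter).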

Compound 3, half-maximal inhibitory concentration: 5460 nM
Compound 3: middle estimate off by 1.6-fold (0.19 log units), on the low side; the measured number falls inside the stated range.
By their numbers in this assay, from the lowest: compounds 2, 3 and 1 (each within the scatter of the next).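

In this assay, putting 4-(hydroxymethyl)piperidin-1-yl in place of diethylamino gives a 1.3-fold higher number from compound 2 to compound 3 (0.11 log units; within the scatter), and the comparison with the isopropyl end gives a 1.6-fold lower number from compound 1 to compound 3 (0.19 log units; within the scatter); both steps stay within the scatter. A six-membered ring and a hydroxyl-bearing arm can therefore be added at this position without a step beyond the scatter. No supporting measurement is available to explain this result. Going by these compounds, whether a morpholine ring or a carboxylic acid here would give a step beyond the scatter remains open.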